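Trifluoromethyl in Place of Ethylamino on the Carbonyl Carbon

The source may report more compounds than this note shows. Statements on the series, on what has been measured and on what is new or still open speak of the compounds shown alone.

Compound 2 `CCNC(=O)NC[C@H]1CN(c2ccc(-n3cc(-c4ccccn4)cn3)c(F)c2)C(=O)O1` stands highest of the two compounds measured in a physicochemical assay for solubility, read by HPLC, with a stated time of 24 h (on this read-out higher numbers stand for higher solubility and lower numbers for lower solubility), where compound 2 gives 222000 nM. Going by the values given here, its only neighbour, compound 1 `O=C1O[C@@H](CSc2cccs2)CN1c1ccc(-n2cc(-c3ccccn3)cn2)c(F)c1`, gives 8500 nM in this assay, and the step of a 26-fold higher number from compound 1 to compound 2 (1.42 log units; beyond the scatter) is large. Compound 3 `O=C1O[C@@H](CNC(=O)C(F)(F)F)CN1c1ccc(-n2cc(-c3ccccn3)cn2)c(F)c1` differs from compound 2 by trifluoromethyl in place of ethylamino on a carbonyl carbon. Among the compounds with values here, no measured step bears directly on this change; the one known step touches a different end of the chain, so the expectation rests on the loss of the ethylamino donor alone. For compound 3 a moderate fall is expected, a 3.2-fold lower number from compound 2 to compound 3 (0.50 log units; beyond the scatter), to an estimated 70000 nM within 20000 nM to 200000 nM.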

Compound 3, solubility: 114000 nM
The estimate for compound 3 lay 1.6-fold (0.21 log units) below the measured number; measured number inside the range.
By their numbers in this assay, from the lowest: compound 1; then compounds 3 and 2 (each within the scatter of the next).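

In this assay, trifluoromethyl in place of ethylamino on a carbonyl carbon gives a 1.9-fold lower number from compound 2 to compound 3 (0.29 log units; within the scatter), so the hydrogen-bond donor of the ethylamino can go at this position with no change that stands clear of the scatter. With ((trifluoromethyl)carbonyl)amino in place of (thiophen-2-yl)sulfanyl, the result is a 13-fold higher number from compound 1 to compound 3 (1.13 log units; beyond the scatter), so the large step from compound 1 does not depend on the ethylamino. No evidence is available to explain either step. From the compounds shown here alone, whether an amine, a carboxylic acid or a longer chain on this carbonyl carbon would stay in the same range remains open.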